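The source may hold more compounds than are shown below. What is called first, only, known or untested is meant among the compounds shown, and "the series" means these compounds.

Of the compounds shown here, two with the shared core have been measured in an ADME assay on UACC-257 cells (Homo sapiens) for cytotoxicity, read by sulforhodamine B assay, with a stated time of 24 h; on this read-out higher numbers stand for lower toxicity in this test and lower numbers for higher toxicity in this test. Compound 1 `COc1ccc(C(=O)/C=C/c2cc3ccccc3[nH]c2=O)cc1` gives 65500 nM in this assay. Compound 2 `O=C(/C=C/c1cc2ccccc2[nH]c1=O)c1ccc(O)cc1` gives 47900 nM in this assay, the lower of the two numbers, and the step of a 1.4-fold lower number from compound 1 to compound 2 (0.14 log units; within the scatter) is too small to count as a real change.

Compound 3 `O=C(/C=C/c1cc2ccccc2[nH]c1=O)c1ccc(Cl)cc1` has not been measured. It differs from compound 2 by chloro in place of hydroxy on an aromatic carbon. Among the measured compounds shown here, the one measured step, the hydrogen-for-methyl exchange from compound 1 to compound 2, touches the same ring but not the same kind of group, so it speaks only loosely to this change; what it does show is that altering this para group left the number within the scatter. On that basis the step is expected to be small: a 1.1-fold lower number from compound 2 to compound 3 (0.03 log units; within the scatter). Compound 3 is therefore estimated at 45000 nM, within a range from 18000 nM to 110000 nM.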

Compound 3, concentration lethal to 50% of the cells: > 100000 nM
Compound 3: a limit, no number (the forecaster's own chance of this, stated with the estimate: 10%); at least 2.2-fold (0.34 log units) between middle value and limit.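

Compound 3 is recorded as a limit of the assay and not as a number: the limit of > 100000 nM in this assay, at which 1 of the 3 values shown sits. Even so, chloro in place of hydroxy gives an at least 2.0-fold higher number from compound 2 to compound 3 (0.31 log units; beyond the scatter) in this assay, so this is the first change at this aromatic carbon that goes beyond the scatter, and it points towards lower toxicity in this test. The comparison with the methoxy compound is less firm: chloro in place of methoxy gives an at least 1.5-fold higher number from compound 1 to compound 3 (0.18 log units; that floor lies within the scatter), so a real difference between these two groups cannot be claimed from this floor.

From the compounds shown here alone, the actual value of compound 3 remains unknown, so the full size of both steps stays open. Also open, going by these compounds, is how an amine, a carboxylic acid or a longer chain on this same carbon would read in this assay.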